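The compounds below may be only part of what the source reports. "The series", "measured", "known", "first", "only" and "open" are said of these compounds alone.

Compound 1, `C=CCC/C=C\C=C/CCCCCCCC[C@H]1CC[C@H]([C@@H]2CC[C@@H](CC(=O)O)OO2)O1`: 0.1 ug/mL in a functional assay on DU-145 cells (Homo sapiens) for cytotoxicity; a lower number here means a stronger inhibitor, a higher number a weaker inhibitor.
Compound 2, `C=CCC/C=C\C=C/CCCCCCCC[C@@H]1CC[C@@H]([C@@H]2CC[C@@H](CC(=O)OC)OO2)O1`: 0.1 ug/mL in this assay.

Both measured compounds carry the same long unsaturated chain on a shared core that holds a cyclic peroxide. Compound 1 stands level with compound 2 at the digits shown; the two numbers agree, and any gap between them lies within the usual scatter, so neither can be called the stronger of the pair. Within the data shown here, no step between two measured compounds that differ in a single place is available, so nothing measured here shows how one isolated change moves the read-out.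

Compound 3, `C=CCC/C=C\C=C/CCCCCCCC[C@H]1CC[C@@H]([C@@H]2CC[C@@H](CC(=O)O)OO2)O1`, is the compound still to be measured. Compared with compound 1 it changes as follows: the two compounds have the same atoms and bonds and differ only in configuration as drawn: 1 of 6 stereo elements differ; a stereocentre at a saturated ring carbon is drawn R in compound 1 and S in compound 3. No group leaves and none enters; only the drawn configuration at one saturated ring carbon is altered.

Among the measured compounds shown here, with no measured step to lean on, a change confined to a single stereocentre is expected to give no step beyond the scatter, so the expected step is no change at the digits printed from compound 1 to compound 3 (within the scatter). Compound 3 is therefore estimated at 0.1 ug/mL in this assay, with a range from 0.04 ug/mL to 0.3 ug/mL.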

Compound 3, half-maximal inhibitory concentration: 0.1 ug/mL
Beside the measured number, compound 3's estimate shows no gap at the digits printed; measured number inside the range.
By their numbers in this assay, from the lowest: compounds 1, 2 and 3 (each within the scatter of the next).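

Among these compounds, the first step between two compounds that differ in a single place can now be read: in this assay it shows no change at the digits printed from compound 1 to compound 3 (within the scatter). Among the compounds shown here, until now, the only comparison was between compounds 1 and 2, which differ in more than one place, so the effect of one isolated change could not be seen; now, for this carboxylic acid on this shared core, the cell read-out does not separate the R and S drawings of this saturated ring carbon. The comparison is a clean one, since no group leaves or enters, and the single feature it tests is stated by: the fact that compounds 1 and 3 differ only in the configuration as drawn

The compounds shown leave open whether the other stereocentres can be changed in the same way, since this step speaks for one ring carbon only, and in one cell line. They also leave open what would happen to the read-out with an amide in place of the carboxylic acid, with a shorter saturated chain in place of the long unsaturated one, or with an ether in place of the cyclic peroxide.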